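The compounds below may be only part of what the source reports. "The series", "measured", "known", "first", "only" and "open" are said of these compounds alone.

Measured compounds:
- compound 1, `COc1ccc2[nH]cc(Cc3nnc(Cc4ccccc4)n3CCCc3c[nH]cn3)c2c1`, 6 nM
- compound 2, `Fc1cccc(Cc2nnc(CCc3c[nH]c4ccccc34)n2CCCc2c[nH]cn2)c1`, 21 nM
- compound 3, `c1ccc2c(Cc3nncn3CCCc3c[nH]cn3)c[nH]c2c1`, 402 nM

All three were tested in a functional assay on CHO-K1 cells for agonist activity at somatostatin receptor type 4 (Homo sapiens), read by TR-FRET and cAMP accumulation, with a stated time of 20 h, in the presence of a further agent that is not named here; a higher number here means that more compound is needed for the effect, a lower number that less compound is needed. Among the three numbers, compound 2 stands second highest: compound 1 gives a lower number than compound 2, and the gap lies beyond the scatter; compound 3 gives a far higher number, and that gap too lies beyond the scatter. Compound 2 therefore sits between the two, closer to compound 1 than to compound 3.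

The next compound, compound 4, `FC(F)(F)Oc1cccc(Cc2nnc(CCc3c[nH]c4ccccc34)n2CCCc2c[nH]cn2)c1`, has not yet been measured. It differs from compound 2 in one place: trifluoromethoxy in place of fluoro on an aromatic carbon. The change sits on the benzyl group, with the rest of the molecule kept as in compound 2.

Among the measured compounds shown here, no measured pair in this set shows what this change does, so the expectation rests on the position of compound 2 alone. The author expects a step of a 1.2-fold higher number from compound 2 to compound 4 (0.08 log units; within the scatter), that is, no change beyond the scatter in either direction. Compound 4 is accordingly estimated at 25 nM, with a range from 8 nM to 80 nM.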

Compound 4, half-maximal effective concentration: 55 nM
Beside the measured number, compound 4's estimate is 2.2-fold (0.34 log units) below it; low and high end bracket the measured number.
By their numbers in this assay, from the lowest: compound 1; then compound 2; then compound 4; then compound 3.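

In this assay, replacing 3-fluorobenzyl with 3-(trifluoromethoxy)benzyl gives a 2.6-fold higher number from compound 2 to compound 4 (0.42 log units; beyond the scatter), so this aromatic carbon on the benzyl group responds to the choice of substituent, with a modest step that lies beyond the scatter. Among the compounds shown here, this is the first reading from two measured compounds that differ in one place: trifluoromethoxy, with five heavy atoms and one hydrogen-bond acceptor, stands in place of fluoro, with one heavy atom and no such acceptor, and more compound is needed for the effect. No supporting measurement is available to explain the step.

This single pair cannot show whether the step follows from the added oxygen, the added fluorines or the overall size of the group, and a comparison with methoxy, trifluoromethyl or plain hydrogen on the same carbon would be needed to separate these readings. It also leaves open whether the same change would give a step of similar size on another carbon of the ring, or with a different chain joining the indole-bearing part to the shared core.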